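Hydroxamic acid to carboxylic acid on a peroxide core

A few compounds are considered here, and "the series" means these few. Any claim that something is new, unique, unknown or untested is made for them only; others in the source may bear on it.

The series starts from compound 1, `O=C(NO)[C@H]1CC[C@]2(CC1)OO[C@]1(O2)C2CC3CC(C2)CC1C3`, a hydroxamic acid on a bridged peroxide core. In a functional assay on HL-60 cells (Homo sapiens) for cytotoxicity, read by MTT assay, with a stated time of 48 h (a higher number here means a weaker inhibitor, a lower number a stronger inhibitor), compound 1 reaches only the limit of the test and gives > 50000 nM. Compound 2, `O=C(O)[C@H]1CC[C@]2(CC1)OO[C@]1(O2)C2CC3CC(C2)CC1C3`, keeps the whole core and differs by hydroxy in place of hydroxyamino on a carbonyl carbon. In this assay compound 2 likewise stays at a limit and gives > 100000 nM. The change between them, a step that the two limits leave unreadable from compound 1 to compound 2, cannot be read in size, since both ends are limits: one value sits at the limit of > 100000 nM in this assay, at which 1 of the 3 values shown sits, the other two at the limit of > 50000 nM in this assay, at which 2 of the 3 values shown sit.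

Compound 3, `O=C(NO)[C@H]1CC[C@@]2(CC1)OC[C@]1(OO2)C2CC3CC(C2)CC1C3`, carries the same hydroxamic acid on a core that is rebuilt in more than one place; the difference between the two cores is not broken down here. In this assay compound 3 also gives only a limit, > 50000 nM.

Compound 4, `O=C(O)[C@H]1CC[C@@]2(CC1)OC[C@]1(OO2)C2CC3CC(C2)CC1C3`, has not yet been measured. It stands to compound 3 as compound 2 stands to compound 1, differing by hydroxy in place of hydroxyamino on a carbonyl carbon, the same change at the same kind of place. Since neither compound 1 nor compound 2 gave a readable number, the step that the limit leaves unreadable from compound 3 to compound 4 is estimated to stay hidden in the same way. Compound 4 is therefore expected to give around 100000 nM in this assay, most probably again as a limit, with a range of 50000 nM to 300000 nM.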

Compound 4, half-maximal inhibitory concentration: > 100000 nM
Compound 4 was reported as a limit (the forecaster's own chance of this, stated with the estimate: 85%); the middle value sits exactly at the limit.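

In this assay compound 4 gives > 100000 nM, which is a limit. Since compound 3 also stands at a limit, the change from hydroxycarbamoyl to carboxy between compound 3 and compound 4 cannot be read in size, just as between compound 1 and compound 2. With all four values at limits, the compounds shown leave open how either end group or either core affects the read-out.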